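Swapping a side chain on a purine-amide series in mice

The source may hold more compounds than are shown below. What is called first, only, known or untested is meant among the compounds shown, and "the series" means these compounds.

Compound 1 `NC(=O)CC[C@H](NC(=O)CN(c1nc(Cl)nc2[nH]cnc12)C1CC1)C(=O)OCc1ccccc1` gives 30.8% in a functional assay on the whole organism (Tail, strain ICR) with Mus musculus as the target, in the tail flick test, with a stated time of 30 min, at a dose of 25 umol/kg by the oral route; a lower number here means a weaker effect, a higher number a stronger effect of the compound at the dose given. Compound 2 `CC(C)C[C@H](NC(=O)CN(c1nc(Cl)nc2[nH]cnc12)C1CC1)C(=O)OCc1ccccc1` gives 33.9%. Compound 3 `CC(C)C[C@H](NC(=O)CN(c1nc(Cl)nc2[nH]cnc12)C1CC1)C(=O)O` gives 23.4%.

All three share the same purine-bearing amide; they differ only in the amino-acid part. The change from compound 2 to compound 1, (carbamoylmethyl in place of isopropyl on a saturated chain carbon, two bonds along the chain from an amide-type nitrogen and a carbonyl carbon), moved the number by a number 3.1 percentage points lower from compound 2 to compound 1 (within the scatter), so the two values cannot be told apart. The change from compound 2 to compound 3, (hydrogen in place of benzyl on an oxygen next to a carbonyl group), gave a number 10.5 percentage points lower from compound 2 to compound 3 (beyond the scatter), a modest fall that is real.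

Compound 4 `NC(=O)CC[C@H](NC(=O)CN(c1nc(Cl)nc2[nH]cnc12)C1CC1)C(=O)O` has not yet been measured. Within the data shown here, it is made from compound 3 by carbamoylmethyl in place of isopropyl on a saturated chain carbon, two bonds along the chain from an amide-type nitrogen and a carbonyl carbon, the same change, at the same place, as the one that turned compound 2 into compound 1. The two cores differ only in the way already described by hydrogen in place of benzyl on an oxygen next to a carbonyl group. Since compound 2 lost only a number 3.1 percentage points lower from compound 2 to compound 1 (within the scatter) on this swap, the step from compound 3 to compound 4 is expected to be about a number 2.4 percentage points lower from compound 3 to compound 4 (within the scatter). Compound 4 is therefore estimated at 21%, between 10% and 32%.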

Compound 4, a percentage reported as activity, at one dose (the size of the read-out at that dose, not a potency): 33.1%
The estimate for compound 4 lay 12.1 percentage points below the measured number; measured number above the stated range.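

In this assay, putting carbamoylmethyl in place of isopropyl on the core with the free acid gave a number 9.7 percentage points higher from compound 3 to compound 4 (within the scatter), while putting hydrogen in place of benzyl on the core with the carbamoylmethyl side chain gave a number 2.3 percentage points higher from compound 1 to compound 4 (within the scatter). Set beside its earlier counterpart, the side-chain swap cannot be shown to behave differently on the two cores: the same change on two cores in this assay, a number 3.1 percentage points lower (within the scatter) from compound 2 to compound 1 and a number 9.7 percentage points higher (within the scatter) from compound 3 to compound 4, 12.8 percentage points apart, within the scatter of two such steps This does not prove that the swap carries over unchanged, since a single pair of steps cannot separate a real shift from scatter, and the change from benzyl to hydrogen gives the same reading: the same change on two cores in this assay, a number 10.5 percentage points lower (beyond the scatter) from compound 2 to compound 3 and a number 2.3 percentage points higher (within the scatter) from compound 1 to compound 4, 12.8 percentage points apart, within the scatter of two such steps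

The compounds shown leave open how the swap would behave with a side chain ending in an amine or a carboxylic acid, or on an ester other than benzyl, such as a methyl ester. They also leave open whether the same reading would hold at other doses or times.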